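Series notes: aromatic-nitrogen substituent and phenyl ring variation

A few compounds are considered here, and "the series" means these few. Any claim that something is new, unique, unknown or untested is made for them only; others in the source may bear on it.

Measured so far:
compound 1, `Cc1cc(NC(=O)Cn2nnc(-c3ccccc3)n2)n(C2CCCCC2)n1`: 96 nM
compound 2, `Cc1cc(NC(=O)Cn2nnc(-c3ccccc3)n2)n(C2CCOCC2)n1`: 435 nM
compound 3, `Cc1cc(NC(=O)Cn2nnc(-c3ccccc3)n2)n(C2CC2)n1`: limit only

In an assay on HEK293 cells for activation of Kir3.1/Kir3.2 (Homo sapiens), read by thallium flux (on this read-out lower numbers stand for an effect already at smaller amounts and higher numbers for an effect only at larger amounts of compound), compound 1 gives the lowest of the two numbers shown. Compound 3 reaches only the assay limit of > 5000 nM. The measured steps all concern the group on the aromatic nitrogen: a 4.5-fold higher number from compound 1 to compound 2 (0.66 log units; beyond the scatter), an at least 52-fold higher number from compound 1 to compound 3 (1.71 log units; beyond the scatter) and an at least 11-fold higher number from compound 2 to compound 3 (1.06 log units; beyond the scatter). Compound 4, `Cc1cc(NC(=O)Cn2nnc(-c3cc(Cl)cc(Cl)c3)n2)n(C2CCCCC2)n1`, differs from compound 1 elsewhere: 3,5-dichlorophenyl in place of phenyl on an aromatic carbon. Among the measured compounds shown here, none of the measured steps touches that ring, so they give no direct guide to the size or direction of this step. The expected change is therefore small, a 1.4-fold lower number from compound 1 to compound 4 (0.14 log units; within the scatter), within or near the scatter. For compound 4 the estimate in this assay is 70 nM, expected between 20 nM and 250 nM.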

Compound 4, half-maximal effective concentration: 980 nM
Beside the measured number, compound 4's estimate is 14-fold (1.15 log units) below it, and the stated range ends below it.
By their numbers in this assay, from the lowest: compound 1; then compound 2; then compound 4. At a limit, above all of these: compound 3.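

The ring on the aromatic carbon of the five-membered aromatic ring is not a neutral place in this assay: 3,5-dichlorophenyl in place of phenyl gives a 10-fold higher number from compound 1 to compound 4 (1.01 log units; beyond the scatter). With the cyclohexyl group held constant, this ring moves the number as well as the group on the aromatic nitrogen does, and the two added chlorine atoms go the unfavourable way. No measured property offers a reason for this step.

Open, as far as these compounds go, is whether a single chlorine, a fluorine or a methoxy group on the phenyl ring behaves likewise. Also open, from the compounds shown here alone, is whether the same change carries over to the oxan-4-yl group of compound 2.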